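This account rests on a few compounds, and the source may have more. Where it says the series, first, only, none or still open, it means among the compounds named here.

Measured so far:
compound 1 `CC(C)CC(=O)Nc1cc(-c2ccccc2)nc(-c2ccccc2)n1` — 14.8 nM
compound 2 `CC(C)(C)C(=O)Nc1cc(-c2ccccc2)nc(-c2ccccc2)n1` — 27.7 nM
compound 3 `CC(C)(C)C(=O)Nc1nc(-c2ccccc2)cc(-c2ccccc2)n1` — 224 nM

All three were run in an assay on CHO cells for displacement of a labelled ligand from adenosine receptor A1 (Homo sapiens); on this read-out lower numbers stand for stronger inhibition and higher numbers for weaker inhibition. Compound 1 and compound 2 share one core and differ by isobutyl in place of tert-butyl on a carbonyl carbon; that step, a 1.9-fold lower number from compound 2 to compound 1 (0.27 log units; within the scatter), is within the scatter. Compound 3 carries the other core; the difference between the two cores is not broken down here, but compound 3 gives the highest number of the three.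

Compound 4 `CC(C)CC(=O)Nc1nc(-c2ccccc2)cc(-c2ccccc2)n1` is not yet measured. It differs from compound 3 by isobutyl in place of tert-butyl on a carbonyl carbon, the same change as between compound 2 and compound 1, at the same place. Compound 4 is expected to give 120 nM, between 50 nM and 300 nM, because compound 3 gives 224 nM and the earlier step of a 1.9-fold lower number from compound 2 to compound 1 (0.27 log units; within the scatter) was small. The expected step is a 1.9-fold lower number from compound 3 to compound 4 (0.27 log units; within the scatter).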

Compound 4, inhibition constant: 25.1 nM
The estimate for compound 4 lay 4.8-fold (0.68 log units) above the measured number; the measured number lies below the stated range.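

On the core of compound 3, isobutyl in place of tert-butyl on a carbonyl carbon gives a clear step in this assay, with an 8.9-fold lower number from compound 3 to compound 4 (0.95 log units; beyond the scatter). The size of this step does not carry over from one core to the other: the same change on two cores in this assay, a 1.9-fold lower number (0.27 log units; within the scatter) from compound 2 to compound 1 and an 8.9-fold lower number (0.95 log units; beyond the scatter) from compound 3 to compound 4, 4.8-fold (0.68 log units) apart, beyond the scatter of two such steps. This pair of steps shows that a small step on the core of compound 1 does not predict a small step on the core of compound 3, but it does not show why the two differ, and two steps set no rule for the series.

From the compounds shown here alone, it remains open whether a longer chain or a cyclopropyl group on the carbonyl carbon would also give steps that differ between the two cores. Going by these compounds, it also remains open how a free amine in place of the amide would read on each core.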